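Rat plasma stability of isosorbide diesters and a nitrate

The compounds below may be only part of what the source reports. "The series", "measured", "known", "first", "only" and "open" are said of these compounds alone.

Measured compounds:
compound 1 `COc1ccccc1C(=O)O[C@@H]1CO[C@H]2[C@@H]1OC[C@@H]2OC(=O)c1ccccc1OC(C)=O` — 0.0165 h
compound 2 `COc1cccc(C(=O)O[C@@H]2CO[C@H]3[C@@H]2OC[C@@H]3OC(=O)c2ccccc2OC(C)=O)c1` — 0.0142 h

Among the compounds with values here, compound 2 `COc1cccc(C(=O)O[C@@H]2CO[C@H]3[C@@H]2OC[C@@H]3OC(=O)c2ccccc2OC(C)=O)c1` gives the lowest of the two numbers in an ADME assay on a cell-free system (plasma, Homo sapiens) for metabolic stability, with Plasma (Rattus norvegicus) as the target, read by HPLC, at pH 7.4 (a higher number here means that the compound lasts longer, a lower number that the compound disappears faster), though its only neighbour, compound 1, sits within the scatter, as the step of a 1.2-fold lower number from compound 1 to compound 2 (0.07 log units; within the scatter) shows. Compound 3 `CC(=O)Oc1ccccc1C(=O)O[C@H]1CO[C@H]2[C@@H]1OC[C@H]2O[N+](=O)[O-]` differs from compound 2 in one place: nitro in place of (3-methoxyphenyl)carbonyl on an oxygen on a saturated carbon. Within the data shown here, the single measured step, from compound 1 to compound 2, concerns a change on the other ester and does not bear on this exchange; no step in the data touches the group that is replaced here. The acetylsalicylate ester is kept in both compounds. For compound 3 no step beyond the scatter is therefore expected, and the estimated step is a 1.3-fold higher number from compound 2 to compound 3 (0.10 log units; within the scatter), with a wide range. Compound 3 is expected to give about 0.018 h, between 0.007 h and 0.05 h.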

Compound 3, half-life: 0.00314 h
The estimate for compound 3 lay 5.7-fold (0.76 log units) above the measured number, outside the stated range (below it).
By their numbers in this assay, from the lowest: compound 3; then compounds 2 and 1 (each within the scatter of the next).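

In this assay, the oxygen on a saturated carbon proves to be a place where the exchange counts: nitro in place of (3-methoxyphenyl)carbonyl gives a clear step (a 4.5-fold lower number from compound 2 to compound 3 (0.66 log units; beyond the scatter)), and nitro in place of (2-methoxyphenyl)carbonyl gives a similar one (a 5.3-fold lower number from compound 1 to compound 3 (0.72 log units; beyond the scatter)). The earlier pair differed only in the 3-methoxyphenyl and 2-methoxyphenyl groups and stayed within the scatter, whereas replacing the whole carbonyl group, with 10 heavy atoms leaving and 3 entering, takes the number beyond it, towards faster disappearance. Nothing available here accounts for this step.

The compounds shown leave open whether the number follows the nitro group itself or the departure of the aromatic carbonyl group, a question on which a hydroxyl, an acetyl or a longer chain on that oxygen would bear. Going by these compounds, the acetylsalicylate ester is the same in all three compounds, so its share in these numbers also stays open.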